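Taking the aminomethyl group off compound 2

A few compounds are considered here, and "the series" means these few. Any claim that something is new, unique, unknown or untested is made for them only; others in the source may bear on it.

In a functional assay on PC-6 cells (Homo sapiens) for cytotoxicity, read by MTT assay, with a stated time of 3 days (a higher number here means a weaker inhibitor, a lower number a stronger inhibitor), compound 1 `CN(C)Cc1ccc(/C=N/Nc2ncnc3sc(C(C)(C)C)cc23)cc1` gives 0.107 ug/mL, compound 2 `CC(C)(C)c1cc2c(N/N=C/c3ccc(CN)cc3)ncnc2s1` gives 0.214 ug/mL and compound 3 `CN1Cc2ccc(/C=N/Nc3ncnc4sc(C(C)(C)C)cc34)cc2C1` gives 0.05 ug/mL. Compound 2 therefore stands level with compound 1 within the scatter, while compound 3 has the lower number. Compound 4 `CC(C)(C)c1cc2c(N/N=C/c3ccccc3)ncnc2s1` differs from compound 2 as follows: hydrogen in place of aminomethyl on an aromatic carbon. Going by the values given here, the only measured step that bears on this is a 2.0-fold higher number from compound 1 to compound 2 (0.30 log units; within the scatter), which swapped dimethylamino for amino but never removed the group. Among the compounds with values here, it offers weak guidance, since no measured compound lacks that group. A modest rise in this assay is expected, with the estimate being a 1.9-fold higher number from compound 2 to compound 4 (0.27 log units; within the scatter). Compound 4 is estimated at 0.4 ug/mL, with an expected range of 0.1 ug/mL to 1.6 ug/mL.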

Compound 4, half-maximal inhibitory concentration: 6.54 ug/mL
For compound 4 the middle estimate is 16-fold (1.21 log units) below the measured one; the whole stated range lies below it.
By their numbers in this assay, from the lowest: compound 3; then compounds 1 and 2 (each within the scatter of the next); then compound 4.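

Removing the side group altogether, rather than only changing its amine, gives a 31-fold higher number from compound 2 to compound 4 (1.49 log units; beyond the scatter) in this assay, and the same removal counted from the dimethylamino compound gives a 61-fold higher number from compound 1 to compound 4 (1.79 log units; beyond the scatter). At this aromatic carbon, then, having either of these amine-bearing groups matters far more than which of the two is present. Nothing measured here explains why the number rises so sharply. From the compounds shown here alone, it stays open whether the nitrogen or its carbon matters: a plain methyl or hydroxymethyl group at this place would help separate them.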